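This account rests on a few compounds, and the source may have more. Where it says the series, first, only, none or still open, it means among the compounds named here.

Measured in an assay on CHO cells for displacement of a labelled ligand from adenosine receptor A2b (Homo sapiens), read by scintillation counting, with a stated time of 75 min; on this read-out lower numbers stand for stronger inhibition and higher numbers for weaker inhibition:
Compound 1 `O=C(CCCc1ccccc1)Nc1nc2ccccc2c(=O)s1`: > 1000 nM, a limit of the assay rather than a number.
Compound 2 `COc1cccc(CCC(=O)Nc2nc3ccccc3c(=O)s2)c1`: 225 nM.

Compound 1 stands at the limit of > 1000 nM in this assay, at which 1 of the 2 values shown sits, so only a range is known for it. Compound 2, by contrast, gives a firm number. Among the measured compounds shown here, the single measured step, an at least 4.4-fold lower number from compound 1 to compound 2 (0.64 log units; beyond the scatter), changes the far end of the chain and leaves the core untouched. Compound 3 `Cc1ccc2nc(NC(=O)CCCc3ccccc3)sc(=O)c2c1` differs from compound 1 at the core itself: methyl in place of hydrogen on an aromatic carbon. For the measured compounds named here, no measured step touches this aromatic carbon, so the change seen between compound 1 and compound 2 offers no direct guide to the size or direction of the step in this assay. With nothing pointing either way, the expectation is a step no larger than the usual scatter. Since compound 1 itself sits at a limit, compound 3 is expected to land near that limit as well. The estimate for compound 3 in this assay is 1500 nM, within 500 nM to 5000 nM. This corresponds to an expected step that the limit leaves unreadable from compound 1 to compound 3.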

Compound 3, inhibition constant: 408 nM
Compound 3: middle estimate off by 3.7-fold (0.57 log units), on the high side, and the stated range ends above it.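

In this assay, methyl in place of hydrogen on an aromatic carbon of the core gives an at least 2.4-fold lower number from compound 1 to compound 3 (0.38 log units; beyond the scatter). Among the compounds shown here, the earlier step, an at least 4.4-fold lower number from compound 1 to compound 2 (0.64 log units; beyond the scatter), changed only the far end of the chain, so this is the first sign that the core also matters: one added carbon on this aromatic position, with the chain kept as it is, moves the number beyond the scatter. On these data alone, the true size of the methyl step stays unknown, because compound 1 carries a limit and not a number: the limit of > 1000 nM in this assay, at which 1 of the 3 values shown sits.

As far as these compounds go, whether an ethyl group or a chlorine atom on this same carbon would lower the number further or raise it again stays open, as does whether a methyl on another aromatic carbon of the core would have any comparable effect. Also open, from the compounds shown here alone, is what the methyl does when it is paired with the 3-methoxyphenyl end of compound 2, and whether the two changes would add up or not.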